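A few compounds are considered here, and "the series" means these few. Any claim that something is new, unique, unknown or untested is made for them only; others in the source may bear on it.

Measured so far:
- compound 1 `c1cc(Nc2nccc(-c3cccnc3)n2)cc(OCCn2ccnc2)c1` — a functional assay for inhibition, with Homo sapiens as the target; a lower number here means a stronger inhibitor, a higher number a weaker inhibitor: 100 nM
- compound 2 `CN(C)c1cccc(Nc2nccc(-c3ccccn3)n2)c1` — this assay: 400 nM

Of the two measured compounds, compound 2 gives the highest number in this assay, so it is the weaker inhibitor of the pair; compound 1 sits at a lower number, and that gap lies beyond the usual scatter of repeated measurements.

Compound 3 `c1ccc(-c2ccnc(Nc3cccc(OCCn4ccnc4)c3)n2)nc1` is reached from compound 2 by a single change: 2-(1H-imidazol-1-yl)ethoxy in place of dimethylamino on an aromatic carbon. The group that enters is the same 2-(1H-imidazol-1-yl)ethoxy group that compound 1 carries, although compound 1 and compound 3 also differ elsewhere and no direct comparison between them is available.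

Since compound 1, with that group in place, gives 100 nM, the step is expected to lower the number, by roughly a 2.7-fold lower number from compound 2 to compound 3 (0.43 log units; beyond the scatter). Compound 3 is therefore estimated at 150 nM, with a likely range from 50 nM to 500 nM.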

Compound 3, half-maximal inhibitory concentration: 400 nM
Estimate against measurement, compound 3: 2.7-fold (0.43 log units) below, within the range that was stated.
By their numbers in this assay, from the lowest: compound 1; then compounds 2 and 3 (each within the scatter of the next).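

In this assay, the step at this aromatic carbon, 2-(1H-imidazol-1-yl)ethoxy in place of dimethylamino, gives no change at the digits printed from compound 2 to compound 3 (within the scatter), so with pyridin-2-yl on the core the larger group with its five-membered aromatic ring shifts the number no more than the usual scatter. The other step keeps that group and puts pyridin-2-yl in place of pyridin-3-yl, giving a 4.0-fold higher number from compound 1 to compound 3 (0.60 log units; beyond the scatter), which ties the lower number of compound 1 to pyridin-3-yl, a link that compounds 1 and 2 alone could not show, as they differ in two places. No measurement on hand explains either result.

From the compounds shown here alone, whether the two groups at this carbon also match when pyridin-3-yl is present remains open. So does the effect of a primary amine, a carboxylic acid or a longer chain ending in imidazole at this carbon.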